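The compounds below may be only part of what the source reports. "The series", "measured", "known", "first", "only" and "open" are said of these compounds alone.

In a functional assay on DU-145 cells (Homo sapiens) for inhibition, read by trypan blue exclusion, with a stated time of 96 h (on this read-out lower numbers stand for stronger inhibition of growth and higher numbers for weaker inhibition of growth), compound 1 `O=C(/C(=C\c1ccc(O)cc1O)SCc1ccc(Cl)cc1)c1ccc(Cl)cc1` gives 50000 nM. Compound 2 `CN(C)c1ccc(/C=C(/SCc2ccc(Cl)cc2)C(=O)c2ccc(Cl)cc2)cc1` gives > 100000 nM, which is a limit of the assay and not a number, so its standing is known only as that limit (the limit of > 100000 nM in this assay, at which 1 of the 2 values shown sits). Compound 3 `Cc1cc(C)cc(/C=C(/SCc2ccc(Cl)cc2)C(=O)c2ccc(Cl)cc2)c1` differs from compound 2 in one place: 3,5-dimethylphenyl in place of 4-(dimethylamino)phenyl on a double-bonded chain carbon bound to a double-bonded chain carbon. Going by the values given here, the only measured step that bears on this change is the exchange at the same place, an at least 2.0-fold higher number from compound 1 to compound 2 (0.30 log units; that floor lies within the scatter). Its floor lies within the scatter, so it sets no firm size for a change there. In this assay a modest move to a lower number is therefore expected, into the region of compound 1 at 50000 nM. Compound 3 may also reach the limit of the assay. The expected step is an at least 2.2-fold lower number from compound 2 to compound 3 (0.34 log units; beyond the scatter). For compound 3 the estimated value is 45000 nM, with an expected range from 12000 nM to 100000 nM.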

Compound 3, concentration for 50% growth inhibition: 10000 nM
For compound 3 the middle estimate is 4.5-fold (0.65 log units) above the measured one, outside the stated range (below it).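

Compound 3 gives this position its first firm size of change: in this assay, the exchange of 4-(dimethylamino)phenyl for 3,5-dimethylphenyl gives an at least 10-fold lower number from compound 2 to compound 3 (1.00 log units; beyond the scatter). The value of compound 2 is a limit and not a number: the limit of > 100000 nM in this assay, at which 1 of the 3 values shown sits. Measured against a number rather than a limit, 3,5-dimethylphenyl in place of 2,4-dihydroxyphenyl also gives a 5.0-fold lower number from compound 1 to compound 3 (0.70 log units; beyond the scatter), so the group on this double-bonded chain carbon can move growth inhibition by more than the scatter.

The compounds shown leave open whether both methyl groups of 3,5-dimethylphenyl are needed, since a phenyl with a single methyl does not stand among them. They also leave open how a methoxy group, a chlorine or a carboxylic acid at this place would compare.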